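A Methyl-to-Methoxy Swap Carried onto a New Core

A few compounds are considered here, and "the series" means these few. Any claim that something is new, unique, unknown or untested is made for them only; others in the source may bear on it.

Measured compounds:
compound 1, `COc1ccc(-c2cc(NC(=S)NNC(=O)c3ccc(C)cc3)cs2)cc1`: 35000 nM
compound 2, `Cc1ccc(C(=O)NNC(=S)Nc2csc(-c3ccc(C)cc3)c2)cc1`: 37000 nM
compound 3, `Cc1ccc(-c2nnc(Nc3csc(-c4ccccc4)c3)s2)cc1`: "not determined" (no result reported)

In a functional assay on A549 cells (Homo sapiens) for inhibition, read by colorimetric assay and MTT assay, with a stated time of 72 h (a higher number here means a weaker inhibitor, a lower number a stronger inhibitor), compound 2 gives 37000 nM and compound 1 gives 35000 nM. The change between them, (methoxy in place of methyl on an aromatic carbon), made a 1.1-fold lower number from compound 2 to compound 1 (0.02 log units; within the scatter).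

Compound 3, `Cc1ccc(-c2nnc(Nc3csc(-c4ccccc4)c3)s2)cc1`, stands at "not determined" (no result reported) in this assay, so it has no single number there. Its core differs from that of compound 2, but the difference between the two cores is not broken down here. Compound 4, `COc1ccc(-c2nnc(Nc3csc(-c4ccccc4)c3)s2)cc1`, is compound 3 carrying (methoxy in place of methyl on an aromatic carbon), the same change as from compound 2 to compound 1.

With compound 3 unmeasured, no step can be expected for compound 4; only the flat outcome of a 1.1-fold lower number from compound 2 to compound 1 (0.02 log units; within the scatter) and the weak values of compound 1 and compound 2 offer a guide. Compound 4 is estimated at 30000 nM in this assay, expected to lie between 8000 nM and 100000 nM.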

Compound 4, half-maximal inhibitory concentration: 8000 nM
Estimate against measurement, compound 4: 3.8-fold (0.57 log units) above, within the range that was stated.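

Among these compounds, compound 3 has no number here, so no step from it to compound 4 can be read. What the swap from methyl to methoxy does on this core stays open, and nothing shown here accounts for the value of compound 4.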